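The source may report more compounds than this note shows. Statements on the series, on what has been measured and on what is new or still open speak of the compounds shown alone.

Compound 1 `O=C(Nc1cccc(Cl)c1)c1cc(Br)cc(Br)c1O` in an assay on isolated protein for inhibition of thiosulfate sulfurtransferase (Homo sapiens), with a stated time of 60 min, in the absence of a further agent (a higher number here means a weaker inhibitor, a lower number a stronger inhibitor), gives > 100000 nM, which is a limit of the assay.
Compound 2 `COc1c(Br)cc(Br)cc1C(=O)Nc1cccc(Cl)c1` in this assay gives > 100000 nM, again a limit of the assay.
Compound 3 `O=C(Nc1cccc(Cl)c1)c1cc(Br)ccc1O` in this assay gives > 100000 nM, also a limit of the assay.

Compound 2 differs from compound 1 by methyl in place of hydrogen on an oxygen on an aromatic ring. The step that the two limits leave unreadable from compound 1 to compound 2 cannot be sized, as both ends are limits. Compound 3 differs from compound 1 by hydrogen in place of bromo on an aromatic carbon, and the step that the two limits leave unreadable from compound 1 to compound 3 is equally unreadable. Going by the values given here, all three measured values rest at the limit of > 100000 nM in this assay, at which 3 of the 3 values shown sit, so the series so far gives no graded signal at all.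

Compound 4 `COc1ccc(Br)cc1C(=O)Nc1cccc(Cl)c1` has not yet been measured in this assay. It differs from compound 3 by methyl in place of hydrogen on an oxygen on an aromatic ring, the same change already made from compound 1 to compound 2, at a place described in identical words. Because compound 3 sits at > 100000 nM and the earlier methyl-for-hydrogen step that the two limits leave unreadable from compound 1 to compound 2 moved nothing readable, the step from compound 3 to compound 4 is expected to be a step that the limit leaves unreadable from compound 3 to compound 4. Compound 4 is therefore estimated at 150000 nM, within an expected range from 30000 nM to 1000000 nM, most probably reported once more as a limit.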

Compound 4, half-maximal inhibitory concentration: > 100000 nM
Compound 4 gave a limit, no number; the forecaster's own chance of this, stated with the estimate: 85%; the middle value lies beyond the limit too.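

Compound 4 ends at a limit of the assay, as do compound 2 and compound 3, so neither step to compound 4 can be read. All values in this assay rest at one ceiling: the limit of > 100000 nM in this assay, at which 4 of the 4 values shown sit. The compounds shown leave open whether any change to the shared core would give a measurable value, and what size the hydroxy to methoxy or bromo changes would then have.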